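This account rests on a few compounds, and the source may have more. Where it says the series, first, only, none or still open, it means among the compounds named here.

Measured so far in a functional assay on A549 cells (Homo sapiens) for inhibition, read by CCK-8 assay, with a stated time of 72 h, tested at 8 uM; a higher number here means more inhibition of growth at the concentration tested, a lower number less inhibition of growth:
compound 1 `Nc1ccccc1NC(=O)c1ccc(CSc2nccc(C(F)(F)F)n2)cc1` gives 95.1%
compound 2 `Cc1cc(C)cc(SCc2ccc(/C=C/C(=O)Nc3ccccc3N)cc2)c1` gives 47.3%
compound 3 `Nc1ccccc1NC(=O)c1ccc(CSc2ccc(Cl)cc2)cc1` gives 50.4%

Compound 2 holds the lowest of the three numbers. Its nearest neighbour is compound 3, whose value lies within the scatter of it, so no order can be read between these two. Compound 1 stands well above compound 2, beyond the scatter.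

Compound 4 `Nc1ccccc1NC(=O)/C=C/c1ccc(CSCCc2ccccc2)cc1` has not yet been measured. It differs from compound 2 in one place: phenethyl in place of 3,5-dimethylphenyl on a sulfur. The two have the same atoms, joined differently, the change sitting on a sulfur whose other neighbour is a saturated chain carbon. Among the compounds with values here, no measured pair shows this change, so no step can be drawn on for it, and the three measured compounds differ from one another in more than one place.

With nothing to anchor it, a step from compound 2 of a number 4.7 percentage points higher from compound 2 to compound 4 (within the scatter) is expected, not beyond the scatter. Compound 4 is estimated at 52%, between 30% and 75%.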

Compound 4, percent growth inhibition at one concentration: 50.3%
The estimate for compound 4 lay 1.7 percentage points above the measured number; measured number inside the range.
By their numbers in this assay, from the lowest: compounds 2, 4 and 3 (each within the scatter of the next); then compound 1.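

In this assay, within the data shown here, phenethyl in place of 3,5-dimethylphenyl on a sulfur gives a number 3 percentage points higher from compound 2 to compound 4 (within the scatter) and provides the first single-place comparison. The two compounds have the same atoms joined differently, yet this assay does not separate them, so at the one concentration tested this position accepts either group without a readable change. No measurement at hand accounts for this result.

Compound 1 and compound 3 differ from compound 4 in more than one place, so steps to them cannot be read, and this single pair gives no trend for the position. From the compounds shown here alone, whether a longer chain on the sulfur, or an amine or a carboxylic acid on the phenethyl group, would move the number beyond the scatter remains open.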